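Aryl replacement at the chain carbon: toward compound 4

The compounds below may be only part of what the source reports. "The series", "measured", "known", "first", "only" and "open" are said of these compounds alone.

Going by the values given here, in a functional assay on HeLa cells (Homo sapiens) for cytotoxicity, read by MTT assay, with a stated time of 48 h (on this read-out lower numbers stand for stronger inhibition and higher numbers for weaker inhibition), compound 3 `O=C1C(O)=C(C(c2ccc(Cl)cc2)c2c[nH]c3ccccc23)C(=O)c2ccccc21` gives 37000 nM, the highest number among the three compounds measured so far. Compound 1 `O=C1C(O)=C(C(c2ccc(F)cc2)c2c[nH]c3ccccc23)C(=O)c2ccccc21` gives 15800 nM and compound 2 `O=C1C(O)=C(C(c2cccs2)c2c[nH]c3ccccc23)C(=O)c2ccccc21` gives 12400 nM in this assay. Both measured steps into compound 3 run upward: a 2.3-fold higher number from compound 1 to compound 3 (0.37 log units; beyond the scatter) and a 3.0-fold higher number from compound 2 to compound 3 (0.47 log units; beyond the scatter). Between the other two the step of a 1.3-fold lower number from compound 1 to compound 2 (0.11 log units; within the scatter) is small.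

Compound 4 `COc1cccc(C(C2=C(O)C(=O)c3ccccc3C2=O)c2c[nH]c3ccccc23)c1` is not yet measured in this assay. Against compound 3 the change is 3-methoxyphenyl in place of 4-chlorophenyl on a saturated chain carbon bound to an aromatic carbon and a double-bonded ring carbon. Among the compounds with values here, the steps that bear on it are the two that alter the group on this same carbon, since each of them, read away from compound 3, is a modest lower number: a 2.3-fold higher number from compound 1 to compound 3 (0.37 log units; beyond the scatter) and a 3.0-fold higher number from compound 2 to compound 3 (0.47 log units; beyond the scatter) in reverse. Within the data shown here, no measured step involves a methoxy group, so the size is borrowed from those two rather than read directly. A modest downward step is therefore expected, of the order seen for the other two aryl groups, and not a step beyond that.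

The step of a 2.1-fold lower number from compound 3 to compound 4 (0.31 log units; beyond the scatter) is the expected change. Compound 4 is estimated at 18000 nM in this assay, with a range from 7000 nM to 45000 nM.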

Compound 4, half-maximal inhibitory concentration: 25600 nM
Compound 4: middle estimate off by 1.4-fold (0.15 log units), on the low side; measured number inside the range.
By their numbers in this assay, from the lowest: compounds 2, 1, 4 and 3 (each within the scatter of the next, the first and the last beyond it).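

Swapping in 3-methoxyphenyl brings a hydrogen-bond acceptor that 4-chlorophenyl lacks, yet in this assay the result does not separate from the group it replaces, with a 1.4-fold lower number from compound 3 to compound 4 (0.16 log units; within the scatter), or from 4-fluorophenyl, with a 1.6-fold higher number from compound 1 to compound 4 (0.21 log units; within the scatter). Only thiophen-2-yl remains apart from it, with a 2.1-fold higher number from compound 2 to compound 4 (0.31 log units; beyond the scatter), so all four groups at this saturated chain carbon sit within a narrow band whose widest step is a 3.0-fold higher number from compound 2 to compound 3 (0.47 log units; beyond the scatter), and the new substitution pattern on the phenyl ring does not take the number outside that band. No measurement is available that explains these small differences.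

The compounds shown cannot separate the methoxy group itself from where it sits on the phenyl ring, as the series holds only this one methoxy-bearing compound. They also leave open whether an amine, a carboxylic acid or a longer chain in place of the aryl group at this carbon would move the number beyond this band, and whether any change away from this position would do more than the aryl swaps have done.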